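The compounds below may be only part of what the source reports. "The series", "measured", "known", "first", "only" and "open" are said of these compounds alone.

Of the compounds shown here, three built on a shared core have been measured in a functional assay on MKN-45 cells (Homo sapiens) for cytotoxicity, read by MTT assay, with a stated time of 48 h; a lower number here means a stronger inhibitor, a higher number a weaker inhibitor. Compound 1 `C#CCSc1nnc(C)n1N1C(=O)c2ccccc2C1=O` gives only the limit of this assay, > 200000 nM. Compound 2 `C#CCSc1nnc(CC)n1N1C(=O)c2ccccc2C1=O` likewise gives only a limit, > 200000 nM. Within the data shown here, the single one-point step in the set, a step that the two limits leave unreadable from compound 1 to compound 2, therefore has no readable size. Compound 3 `CCCc1nnc(SCC(=O)c2ccc(Cl)cc2)n1N1C(=O)c2ccccc2C1=O` also gives only a limit in this assay, > 200000 nM. Compound 3 thus stands where every measured compound stands, at the limit of > 200000 nM in this assay, at which 3 of the 3 values shown sit, and no number separates it from compound 1 or compound 2.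

Compound 4 `C#CCSc1nnc(CCC)n1N1C(=O)c2ccccc2C1=O` differs from compound 3 by ethynyl in place of (4-chlorophenyl)carbonyl on a saturated chain carbon bound to a sulfur. Among the measured compounds shown here, no measured step covers this change: the only step available, a step that the two limits leave unreadable from compound 1 to compound 2, concerns a different position and cannot be read. Compound 4 carries the same propargyl group that compound 1 and compound 2 carry, and both of those sit at the limit, as does compound 3. Compound 4 is therefore expected to show no step beyond the scatter, with a number no higher from compound 3 to compound 4 (the limit leaves the size open) the estimated change in this assay. Compound 4 is expected to give 200000 nM, within a range from 100000 nM to 500000 nM, most likely again only as a limit.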

Compound 4, half-maximal inhibitory concentration: > 200000 nM
Compound 4: no number, only a limit; the forecaster's own chance of this, stated with the estimate: 85%; the middle value sits exactly at the limit.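

In this assay compound 4 gives > 200000 nM, which is a limit and not a number. The steps to compound 4 from compound 1, compound 2 and compound 3 therefore cannot be read, and all four compounds stay together: the limit of > 200000 nM in this assay, at which 4 of the 4 values shown sit.

The compounds shown leave open whether any change on the shared core can give a measurable value in this assay.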